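The source may hold more compounds than are shown below. What is called first, only, known or untested is meant among the compounds shown, and "the series" means these compounds.

Measured so far:
compound 1 `O=C1NC(=O)/C(=C/c2cc(-c3cccs3)n(-c3ccc(Br)cc3)c2-c2cccs2)S1`: 1280 nM in an assay for inhibition of glutaminase kidney isoform, mitochondrial (Homo sapiens), read by coupled enzyme assay, with stated times of 10 min and 60 min; a higher number here means a weaker inhibitor, a lower number a stronger inhibitor
compound 2 `COc1cc(-n2c(C)cc(/C=C3\SC(=O)NC3=O)c2C)ccc1-c1ccc(/C=C2\SC(=O)NC2=O)cc1`: 355 nM in this assay
compound 3 `CCc1cc(-c2ccc(-n3c(C)cc(/C=C4\SC(=O)NC4=O)c3C)cc2C#N)ccc1/C=C1\SC(=O)NC1=O`: 92 nM in this assay

Among these three, compound 2 holds the middle number in this assay. Compound 1 gives a higher number than compound 2, and the gap between the two lies beyond the scatter. Compound 3 gives a lower number than compound 2, and that gap also lies beyond the scatter. Going by the values given here, no single-point step connects any pair of the measured compounds, so the values stand on their own.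

Compound 4 `Cc1cc(/C=C2\SC(=O)NC2=O)c(C)n1-c1ccc(-c2ccc(/C=C3\SC(=O)NC3=O)cc2)c(O)c1` differs from compound 2 in one place: hydrogen in place of methyl on an oxygen on an aromatic ring. No measured pair shows this change, so its size is unknown from the data shown here. The change is expected to move the number little, if at all, beyond the scatter. For compound 4 in this assay the estimate is 300 nM, with a range from 120 nM to 800 nM. The expected step of a 1.2-fold lower number from compound 2 to compound 4 (0.07 log units; within the scatter) is small.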

Compound 4, half-maximal inhibitory concentration: 760 nM
Compound 4: middle estimate off by 2.5-fold (0.40 log units), on the low side, within the range that was stated.
By their numbers in this assay, from the lowest: compound 3; then compound 2; then compounds 4 and 1 (each within the scatter of the next).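

Going by these compounds alone, this pair is the only single-point step available: going from methoxy to hydroxy, with hydrogen in place of methyl on an oxygen on an aromatic ring, gives a 2.1-fold higher number from compound 2 to compound 4 (0.33 log units; beyond the scatter) in this assay for this pair. The position is therefore not indifferent to this change, since removing the methyl weakens inhibition modestly but measurably. No supporting data bear on why the number rises, so the step stands as an observation from a single pair.

From the compounds shown here alone, how an ethoxy group, an amine or a fluorine at this place on the aromatic ring would compare with the methoxy of compound 2 remains open. A single pair also cannot show whether the same change would have a similar effect in a different compound, such as compound 3.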